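The source may hold more compounds than are shown below. What is called first, only, known or untested is meant among the compounds shown, and "the series" means these compounds.

In an ADME assay on the whole organism for metabolic stability, with Rattus norvegicus as the target (on this read-out lower numbers stand for a shorter-lived compound and higher numbers for a longer-lived compound), compound 1 (`O=C(Nc1cccnc1-c1ccsc1)N1CCN2C(=O)N([C@H]3C[C@@H]3c3ccccc3)C(=O)[C@@H]2C1`) gives 10 h, compound 3 (`O=C(Nc1cccnc1-c1cccc(Cl)c1)N1CCN2C(=O)N([C@H]3C[C@@H]3c3ccccc3)C(=O)[C@@H]2C1`) gives 1.3 h and compound 2 (`CN(C)C(=O)c1cc(Cl)c(NC(=O)N2CCN3C(=O)N([C@H]4C[C@@H]4c4ccccc4)C(=O)[C@@H]3C2)c(Cl)c1`) gives 0.6 h, the lowest of these three numbers. Compound 4 (`CS(=O)(=O)c1cc(Cl)c(NC(=O)N2CCN3C(=O)N([C@H]4C[C@@H]4c4ccccc4)C(=O)[C@@H]3C2)c(Cl)c1`) differs from compound 2 in one place: methylsulfonyl in place of dimethylcarbamoyl on an aromatic carbon, meta to two chloro groups and para to a large group (methylsulfonyl in place of dimethylcarbamoyl on an aromatic carbon). Going by the values given here, the only measured step, a 7.7-fold lower number from compound 1 to compound 3 (0.89 log units; beyond the scatter), puts 3-chlorophenyl in place of thiophen-3-yl, a different exchange at a different place, so it offers little guidance here. Among the compounds with values here, no measured step covers this exchange. In this assay the expected step is therefore small, a 1.3-fold higher number from compound 2 to compound 4 (0.12 log units; within the scatter), staying within the scatter. Compound 4 is estimated at 0.8 h, with an expected range of 0.3 h to 2.5 h.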

Compound 4, half-life: 3.2 h
Estimate against measurement, compound 4: 4.0-fold (0.60 log units) below; the measured number lies above the stated range.
By their numbers in this assay, from the lowest: compound 2; then compound 3; then compound 4; then compound 1.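

In this assay, the exchange of dimethylcarbamoyl for methylsulfonyl, on the aromatic carbon meta to two chloro groups and para to a large group, gives a 5.3-fold higher number from compound 2 to compound 4 (0.73 log units; beyond the scatter), a step beyond the usual scatter. So the group at this position bears on the half-life, which the earlier compounds, differing only elsewhere, could not show. Nothing measured here explains the step.

Still open, as far as these compounds go, is whether other groups at this carbon, such as a nitrile or a carboxylic acid, would give a longer or shorter half-life. From the compounds shown here alone, the role of the two chloro groups in this step also remains unknown.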